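This account rests on a few compounds, and the source may have more. Where it says the series, first, only, none or still open, it means among the compounds named here.

Measured compounds:
compound 1, `COc1cccc(OS(=O)(=O)c2ccc(N3CCN(C)C3=O)cc2)c1`: 2500 nM
compound 2, `CN1CCN(c2ccc(S(=O)(=O)Oc3cccc(F)c3)cc2)C1=O`: > 100000 nM
compound 3, `CCCN1CCN(c2ccc(S(=O)(=O)Oc3cccc(OC)c3)cc2)C1=O`: 25000 nM

In a functional assay on HT-29 cells (Homo sapiens) for antiproliferative activity, read by sulforhodamine B assay, with a stated time of 48 h (on this read-out lower numbers stand for stronger inhibition and higher numbers for weaker inhibition), compound 1 gives 2500 nM. Compound 2 gives no number, only the limit > 100000 nM, which is the limit of > 100000 nM in this assay, at which 1 of the 3 values shown sits. Compound 3 gives 25000 nM in this assay, a 10-fold higher number from compound 1 to compound 3 (1.00 log units; beyond the scatter). The cores of compound 1 and compound 3 differ by ethyl in place of hydrogen on a saturated chain carbon bound to an amide-type nitrogen in a ring.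

The change from compound 1 to compound 2 is fluoro in place of methoxy on an aromatic carbon, and it produced an at least 40-fold higher number from compound 1 to compound 2 (1.60 log units; beyond the scatter). Compound 4, `CCCN1CCN(c2ccc(S(=O)(=O)Oc3cccc(F)c3)cc2)C1=O`, not yet measured, carries the same change on the core of compound 3: fluoro in place of methoxy on an aromatic carbon. The place is the same word for word in both pairs, so this is the same change.

A step of comparable size is expected from compound 3 to compound 4, an 8.0-fold higher number from compound 3 to compound 4 (0.90 log units; beyond the scatter), resting on the step seen an at least 40-fold higher number from compound 1 to compound 2 (1.60 log units; beyond the scatter) applied to the value of compound 3, 25000 nM. Since compound 3 already stands above compound 1, compound 4 is expected to reach or pass the limit (the limit of > 100000 nM in this assay, at which 1 of the 3 values shown sits). The estimate for compound 4 in this assay is 200000 nM, expected between 60000 nM and 1000000 nM.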

Compound 4, half-maximal inhibitory concentration: 18000 nM
Compound 4: middle estimate off by 11-fold (1.05 log units), on the high side; the whole stated range lies above it.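

On the core of compound 3, fluoro in place of methoxy gives a 1.4-fold lower number from compound 3 to compound 4 (0.14 log units; within the scatter) in this assay, so the change that counted on the core of compound 1 has no readable effect here: the same change on two cores in this assay, an at least 40-fold higher number (1.60 log units; beyond the scatter) from compound 1 to compound 2 and a 1.4-fold lower number (0.14 log units; within the scatter) from compound 3 to compound 4, at least 55-fold (1.74 log units) apart, beyond the scatter of two such steps. The ethyl in place of hydrogen change also fails to carry over between cores, giving an at least 5.5-fold lower number from compound 2 to compound 4 (0.74 log units; beyond the scatter) on the fluoro pair, opposite in direction to the step on the methoxy pair: the same change on two cores in this assay, a 10-fold higher number (1.00 log units; beyond the scatter) from compound 1 to compound 3 and an at least 5.5-fold lower number (0.74 log units; beyond the scatter) from compound 2 to compound 4, at least 55-fold (1.74 log units) apart, beyond the scatter of two such steps. Compound 2 carries only a limit, > 100000 nM, so the exact size of these gaps stays unknown, and two pairs give neither a general rule for the series nor a reason for the difference.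

Still open, from the compounds shown here alone, is whether this dependence on the core extends to other groups on the aromatic ring, such as chloro or a nitrile. The same question stands for a longer chain on the amide-type nitrogen in the ring, such as butyl, or for a chain ending in an amine.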